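Removing the Bromophenyl Arm: What Compound 4 Might Show

This account rests on a few compounds, and the source may have more. Where it says the series, first, only, none or still open, it means among the compounds named here.

Three compounds share a long chain ending in a trifluoromethyl hydrate and an amide. In a functional assay on HCT-116 cells (Homo sapiens) for inhibition, read by colorimetric assay, with a stated time of 3 days (on this read-out higher numbers stand for weaker inhibition and lower numbers for stronger inhibition), compound 1 `COc1ccc(OC)c(NC(=O)CCCCCCNC(=O)C(O)(O)C(F)(F)F)c1` gives 3870 nM, compound 2 `O=C(CCCCCCNC(=O)C(O)(O)C(F)(F)F)Nc1ncc(-c2ccc(Br)cc2)s1` gives 2460 nM, and compound 3 `COc1cc(NC(=O)CCCCCCNC(=O)C(O)(O)C(F)(F)F)cc(OC)c1OC` gives 14100 nM. Compound 2 holds the lowest number of the three; compound 1 sits within the scatter of it, while compound 3 lies beyond it. Compound 4 `O=C(CCCCCCNC(=O)C(O)(O)C(F)(F)F)Nc1nccs1` is not yet measured. Its change from compound 2 is hydrogen in place of 4-bromophenyl on an aromatic carbon. Among the compounds with values here, no comparable step between measured compounds exists, so the direction rests on judgement: the expectation is a weakening, a step of moderate size, because compound 2 carries the low value 2460 nM. Compound 4 is expected to give 8000 nM, within 3000 nM to 25000 nM, a step of a 3.3-fold higher number from compound 2 to compound 4 (0.51 log units; beyond the scatter).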

Compound 4, half-maximal inhibitory concentration: 10800 nM
The estimate for compound 4 lay 1.4-fold (0.13 log units) below the measured number, within the range that was stated.
By their numbers in this assay, from the lowest: compounds 2 and 1 (each within the scatter of the next); then compounds 4 and 3 (each within the scatter of the next).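

In this assay, putting hydrogen in place of 4-bromophenyl on the aromatic carbon next to the ring sulfur gives a 4.4-fold higher number from compound 2 to compound 4 (0.64 log units; beyond the scatter). This position is therefore not indifferent to what it carries, although inhibition does not vanish when the arm is gone. Nothing measured here explains the change.

Still open, going by these compounds, is which part of the arm matters. A plain phenyl group without the bromine, or a small methyl group on the same carbon, could help separate the contribution of the six-membered ring from that of the bromine.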